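This account rests on a few compounds, and the source may have more. Where it says the series, first, only, none or still open, it means among the compounds named here.

Compound 1, `O=[N+]([O-])c1ccc(O)c(CSc2ncnc3c2ncn3[C@@H]2O[C@H](CO)[C@@H](O)[C@H]2O)c1`, gives 33.1 nM in an assay on isolated protein for binding affinity to Equilibrative nucleoside transporter 1 (Homo sapiens); a lower number here means a stronger inhibitor, a higher number a weaker inhibitor. Compound 2, `Cc1ccc(CSc2ncnc3c2ncn3[C@@H]2O[C@H](CO)[C@@H](O)[C@H]2O)cc1`, gives 457 nM.

Compound 2 stands at the highest of the two numbers; its nearest neighbour is compound 1, reached by a 14-fold higher number from compound 1 to compound 2 (1.14 log units; beyond the scatter), a large step beyond the scatter. Compound 3, `OC[C@H]1O[C@@H](n2cnc3c(CSc4ccc(F)cc4)ncnc32)[C@H](O)[C@@H]1O`, has not yet been measured. It differs from compound 2 in one place: ((4-fluorophenyl)sulfanyl)methyl in place of (4-methylbenzyl)sulfanyl on an aromatic carbon. Within the data shown here, the only measured step, from compound 1 to compound 2, exchanges the substituents on the aromatic ring while keeping (4-methylbenzyl)sulfanyl's arrangement, so it does not speak directly to this change; no measured pair shows what the entering group does. With so little to go on, the step of a 1.3-fold higher number from compound 2 to compound 3 (0.12 log units; within the scatter) is expected to stay within the scatter, in either direction. Compound 3 is therefore estimated at 600 nM, with a wide range from 150 nM to 2500 nM.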

Compound 3, half-maximal inhibitory concentration: 158 nM
Beside the measured number, compound 3's estimate is 3.8-fold (0.58 log units) above it; low and high end bracket the measured number.
By their numbers in this assay, from the lowest: compound 1; then compound 3; then compound 2.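

Compound 3 rearranges the side group on the aromatic carbon: in ((4-fluorophenyl)sulfanyl)methyl, a chain carbon rather than sulfur is attached to the core, and fluorine replaces the methyl on the benzene ring. This change gives a 2.9-fold lower number from compound 2 to compound 3 (0.46 log units; beyond the scatter), a modest step that lies beyond the scatter, so a different arrangement with the same count of 9 heavy atoms can still give a lower number at this position. No measurement shown here explains why the number falls.

As far as these compounds go, the order of the sulfur and chain carbon changes together with the swap of methyl for fluorine, so the share of the step belonging to each remains open. Also open, from the compounds shown here alone, is how an amine or a longer chain would fare on this aromatic carbon.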